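This account rests on a few compounds, and the source may have more. Where it says the series, first, only, none or still open, it means among the compounds named here.

Compound 1, `CCCCCNC(=O)Oc1ccc(Cl)cc1C(=O)Nc1ccc(Cl)c(Cl)c1`, gives 5.67 in a physicochemical assay for lipophilicity; a higher number here means a more lipophilic compound, a lower number a more polar compound.
Compound 2, `CCCCCCNC(=O)Oc1ccc(Cl)cc1C(=O)Nc1ccc(Cl)c(Cl)c1`, gives 6.08 in this assay.
Compound 3, `CCCCCNC(=O)Oc1ccc(Cl)cc1C(=O)Nc1ccc(Cl)cc1`, gives 5.11 in this assay.

Compound 4, `CCCCCCNC(=O)Oc1ccc(Cl)cc1C(=O)Nc1ccc(Cl)cc1`, has not yet been measured in this assay. It differs from compound 3 in one place: methyl in place of hydrogen on a saturated chain carbon, five bonds along the chain from an amide-type nitrogen. The same change has already been made once among the measured compounds, from compound 1 to compound 2, where it is methyl in place of hydrogen on a saturated chain carbon, five bonds along the chain from an amide-type nitrogen. There it produced a number 0.41 log units higher from compound 1 to compound 2 (beyond the scatter). The two cores on which this change sits are not identical: compound 3 differs from compound 1 by hydrogen in place of chloro on an aromatic carbon, and that difference gave a number 0.56 log units lower from compound 1 to compound 3 (beyond the scatter). The place of the methyl-for-hydrogen change is described in exactly the same words for both pairs, so it counts as the same change, carried onto a core that lacks one chloro group.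

For compound 4 the expected step is a number 0.41 log units higher from compound 3 to compound 4 (beyond the scatter), because the earlier instance gave a number 0.41 log units higher from compound 1 to compound 2 (beyond the scatter) and nothing in the data suggests the second core would behave differently. Compound 4 is therefore estimated at 5.52 in this assay, expected to fall between 5.2 and 5.85.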

Compound 4, partition coefficient: 5.53
Compound 4: middle estimate off by 0.01 log units, on the low side; measured number inside the range.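

In this assay, the methyl-for-hydrogen change gave a number 0.42 log units higher from compound 3 to compound 4 (beyond the scatter), about the same size as a number 0.41 log units higher from compound 1 to compound 2 (beyond the scatter), so in these two pairs the change carried over from one core to the other. Read the other way, the hydrogen-for-chloro change gave a number 0.55 log units lower from compound 2 to compound 4 (beyond the scatter), close to a number 0.56 log units lower from compound 1 to compound 3 (beyond the scatter), so across these four compounds the two changes simply add up, and none of the four goes against this. This rests on just two pairs for each change, so it does not show that the step would hold on any other core, and nothing measured here explains why the steps agree.

The compounds shown leave open whether the same step would hold for a longer chain, or for a chain ending in an amine or a carboxylic acid. They also leave open whether a fluoro or methoxy group in place of the chloro would add up in the same way.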